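Swapping a Bromine for a Methoxy Group on the Side Ring

A few compounds are considered here, and "the series" means these few. Any claim that something is new, unique, unknown or untested is made for them only; others in the source may bear on it.

Measured so far:
Compound 1 `OC(CCn1nc2c(Br)c(Br)c(Br)c(Br)c2n1)c1cccc(Br)c1`: 118%
Compound 2 `OC(CCn1nc2c(Br)c(Br)c(Br)c(Br)c2n1)c1ccc(F)cc1`: 101%

Both were tested in a functional assay on CCRF-CEM cells (Homo sapiens) for antiproliferative activity, read by MTT assay, with a stated time of 48 h, tested at 12.5 uM; a higher number here means a weaker effect of the compound at the concentration tested, a lower number a stronger effect. For the measured compounds named here, compound 1 gives 118%, the highest of the two numbers; the only other compound, compound 2, sits lower, and the step of a number 17 percentage points lower from compound 1 to compound 2 (beyond the scatter) is the one comparison available. Compound 3 `COc1cccc(C(O)CCn2nc3c(Br)c(Br)c(Br)c(Br)c3n2)c1` has not yet been measured. It differs from compound 1 in a single place: methoxy in place of bromo on an aromatic carbon. Going by the values given here, no measured step matches this change: the step from compound 1 to compound 2 altered both the group and where it sits on the ring, so it offers only a rough sense of how much such a change in this part of the molecule can move the number. The expectation for compound 3 is therefore a small shift, if any beyond the usual scatter, estimated as a number 10 percentage points lower from compound 1 to compound 3 (within the scatter). Compound 3 is expected to give about 108%, within a range of 90% to 125%.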

Compound 3, a percentage reported as activity, at one concentration (the size of the read-out at that concentration, not a potency): 96%
Beside the measured number, compound 3's estimate is 12 percentage points above it; measured number inside the range.
By their numbers in this assay, from the lowest: compounds 3 and 2 (each within the scatter of the next); then compound 1.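

In this assay, for the compounds shown here, exchanging bromo for methoxy gives a number 22 percentage points lower from compound 1 to compound 3 (beyond the scatter) and so shows, for the first time, that changing only the group on this aromatic carbon, with its place on the ring kept, is enough to move the number beyond the scatter. The other comparison gives a number 5 percentage points lower from compound 2 to compound 3 (within the scatter) and so the 3-methoxyphenyl and 4-fluorophenyl compounds cannot be told apart here, which leaves compound 1 with its 3-bromophenyl group alone at the weak end of this small set. Nothing available here accounts for the step from bromo to methoxy.

Still open, on these data alone, is whether methoxy would give the same result on another carbon of this ring. An amine or a carboxylic acid on this same carbon would show whether the number can fall by more than a modest step.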